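Working notes: hydroxy to chloro, compound 3 to compound 4

The source may hold more compounds than are shown below. What is called first, only, known or untested is meant among the compounds shown, and "the series" means these compounds.

Measured so far in a functional assay on HepG2 cells (Homo sapiens) for cytotoxicity, read by sulforhodamine B assay, with a stated time of 24 h; a higher number here means a weaker inhibitor, a lower number a stronger inhibitor:
compound 1, `O=C1Nc2ccc(S(=O)(=O)N3CCOCC3)cc2/C1=N/NC(=O)c1ccccc1`: 18100 nM
compound 2, `N#CCC(=O)N/N=C1\C(=O)Nc2ccc(S(=O)(=O)N3CCOCC3)cc21`: 7530 nM
compound 3, `O=C1Nc2ccc(S(=O)(=O)N3CCOCC3)cc2/C1=N/c1ccc(O)cc1`: 10400 nM

Compound 3 stands second highest of the three numbers in this assay; the nearest is a 1.4-fold higher number from compound 2 to compound 3 (0.14 log units; within the scatter), the furthest a 1.7-fold lower number from compound 1 to compound 3 (0.24 log units; within the scatter), both within the scatter. Compound 4, `O=C1Nc2ccc(S(=O)(=O)N3CCOCC3)cc2/C1=N/c1ccc(Cl)cc1`, differs from compound 3 at one place: chloro in place of hydroxy on an aromatic carbon. For the measured compounds named here, no measured step touches this aromatic carbon; the steps that exist change the group on the double-bonded nitrogen or on a carbonyl carbon, as in a 2.4-fold lower number from compound 1 to compound 2 (0.38 log units; beyond the scatter), and those spread the numbers only modestly. With nothing bearing on the change directly, a step in this assay beyond the scatter is not expected, in either direction. Compound 4 is expected at 9000 nM, with a range of 3500 nM to 25000 nM, which means an expected step of a 1.2-fold lower number from compound 3 to compound 4 (0.06 log units; within the scatter).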

Compound 4, half-maximal inhibitory concentration: 11800 nM
Compound 4: middle estimate off by 1.3-fold (0.12 log units), on the low side; the measured number falls inside the stated range.
By their numbers in this assay, from the lowest: compounds 2, 3, 4 and 1 (each within the scatter of the next, the first and the last beyond it).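

In this assay, the first change shown on this aromatic carbon, chloro in place of hydroxy, leaves the number within the scatter (a 1.1-fold higher number from compound 3 to compound 4 (0.05 log units; within the scatter)), so this position has so far shown no sensitivity to this exchange. The 4-chlorophenyl group also stays within the scatter of both acylamino groups on the double-bonded nitrogen (a 1.6-fold higher number from compound 2 to compound 4 (0.20 log units; within the scatter); a 1.5-fold lower number from compound 1 to compound 4 (0.19 log units; within the scatter)). Nothing available offers an explanation for this result.

As far as these compounds go, it remains open whether an amine, a carboxylic acid or a longer chain on this aromatic carbon would produce a step beyond the scatter.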